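A few compounds are considered here, and "the series" means these few. Any claim that something is new, unique, unknown or untested is made for them only; others in the source may bear on it.

In an ADME assay on L6 cells (Rattus norvegicus) for cytotoxicity (a lower number here means a stronger inhibitor, a higher number a weaker inhibitor), two compounds built on a shared core have been measured so far. Compound 1 `COc1cc2c(cc1C(C)OCc1ccccc1)C=CC(C)(C)O2` gives 43900 nM. Compound 2 `COc1cc2c(cc1C(C)NCCCc1ccccc1)C=CC(C)(C)O2` gives 1080 nM, the lower of the two numbers, and the gap between them lies well beyond the scatter of repeat measurements. Compound 2 is therefore the stronger inhibitor of this pair.

The next compound to be tested is compound 3 `COc1cc2c(cc1C(C)NC/C=C/c1ccccc1)C=CC(C)(C)O2`, which differs from compound 2 in one place: 2-phenylethenyl in place of phenethyl on a saturated chain carbon bound to an amine nitrogen. In plain terms, 2-phenylethenyl stands in place of phenethyl on a saturated chain carbon bound to an amine nitrogen. Going by the values given here, no measured pair yet shows what a change of this kind does in this assay. The expectation therefore starts from compound 2 and its 1080 nM, with no large shift assumed for so limited an edit. The expected change, a 1.4-fold higher number from compound 2 to compound 3 (0.14 log units; within the scatter), is a slight move towards a higher number that stays within the scatter. The estimated value for compound 3 is 1500 nM, with an expected range from 500 nM to 4500 nM.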

Compound 3, half-maximal inhibitory concentration: 14600 nM
The estimate for compound 3 lay 9.7-fold (0.99 log units) below the measured number; the measured number lies above the stated range.
By their numbers in this assay, from the lowest: compound 2; then compound 3; then compound 1.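

On a saturated chain carbon bound to an amine nitrogen, the swap of phenethyl for 2-phenylethenyl looks minor on paper: both groups have the same count of heavy atoms, one six-membered aromatic ring, no hydrogen-bond donors or acceptors and no net charge, and the entering group differs by one double bond outside aromatic rings. Even so, this assay records a 14-fold higher number from compound 2 to compound 3 (1.13 log units; beyond the scatter) and makes compound 3 the weaker inhibitor of this pair, so this position is sensitive to a change that leaves all those counts the same. No measurement shown bears on what lies behind this step.

One step at this position cannot show whether other groups would stay close to compound 2 or move as far as compound 3, for example a benzyl group or a longer chain such as 4-phenylbutyl in place of phenethyl. From the compounds shown here alone, it also remains open whether a triple bond in place of the double bond, or a cyclohexyl ring in place of the phenyl ring of compound 3, would bring a similar rise in the number.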